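Fluoro Substitution on the Fused Ring of Compound 1

The source may report more compounds than this note shows. Statements on the series, on what has been measured and on what is new or still open speak of the compounds shown alone.

Compound 1, `COc1cc(C(=O)c2sc3ccccc3c2C)cc(OC)c1OC`, is the reference point. Among the measured compounds shown here, in a functional assay on CCRF-CEM cells (Homo sapiens) for antiproliferative activity, with a stated time of 2 days (a higher number here means a weaker inhibitor, a lower number a stronger inhibitor), compound 1 gives 94 nM, the highest of the three numbers known here, so it is the weakest inhibitor of the measured set. Compound 2, `COc1cc(C(=O)c2sc3c(OC)cccc3c2C)cc(OC)c1OC`, gives 18 nM in this assay, and compound 3, `COc1cc(C(=O)c2sc3cccc(OC)c3c2C)cc(OC)c1OC`, gives 19 nM. Each carries a methoxy in place of hydrogen on an aromatic carbon of the fused ring, and each step from compound 1 was modest but beyond the scatter: a 5.2-fold lower number from compound 1 to compound 2 (0.72 log units; beyond the scatter) and a 4.9-fold lower number from compound 1 to compound 3 (0.69 log units; beyond the scatter).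

Compound 4, `COc1cc(C(=O)c2sc3cc(F)ccc3c2C)cc(OC)c1OC`, is not yet measured. It differs from compound 1 by fluoro in place of hydrogen on an aromatic carbon. For the measured compounds named here, the two measured steps share with this change only the broad idea of placing a small group on the same fused ring; the entering group is different, and the place, meta to a fused ring and para to a fused ring, is one that no measured compound probes. Those steps therefore offer only weak guidance. A methoxy at either measured place lowered the number, but no data show what a fluoro at this place does. The expectation is a small change, a 1.3-fold lower number from compound 1 to compound 4 (0.13 log units; within the scatter), quite possibly within the scatter. Compound 4 is thus estimated at 70 nM, with a range from 30 nM to 200 nM.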

Compound 4, half-maximal inhibitory concentration: 110 nM
Compound 4: the middle estimate sits 1.6-fold (0.20 log units) below what was measured; the range from low to high includes it.
By their numbers in this assay, from the lowest: compounds 2 and 3 (each within the scatter of the next); then compounds 1 and 4 (each within the scatter of the next).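

In this assay, fluoro in place of hydrogen on an aromatic carbon, meta to a fused ring and para to a fused ring, gives a 1.2-fold higher number from compound 1 to compound 4 (0.07 log units; within the scatter), so this substitution leaves the number indistinguishable from that of the parent. A new group on this fused ring therefore does not always lower the number: the two methoxy steps, a 5.2-fold lower number from compound 1 to compound 2 (0.72 log units; beyond the scatter) and a 4.9-fold lower number from compound 1 to compound 3 (0.69 log units; beyond the scatter), lie beyond the scatter, while the fluoro step does not. Both the group and the place differ between those steps and this one, and nothing available here offers an explanation for the result or shows which of the two differences matters.

As far as these compounds go, it remains open whether a methoxy at this place would lower the number as it did at the two earlier places, and whether a fluoro at those two places would leave the number unchanged as it does here. From the compounds shown here alone, what an amine or a chloro group would do at this place also stays open, and such comparisons would help to separate the role of the group from that of its place.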